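Swapping an Isopropyl for a Hydroxyethyl on the Shared Core

The source may hold more compounds than are shown below. What is called first, only, known or untested is meant among the compounds shown, and "the series" means these compounds.

Compound 1 `CC(C)[C@H](NC(=O)CN(c1ncnc2c1ncn2C1CCCCO1)C1CC1)C(=O)OCc1ccccc1`: 25.8%
Compound 2 `NC(=O)C[C@H](NC(=O)CN(c1nc(Cl)nc2[nH]cnc12)C1CC1)C(=O)OCc1ccccc1`: 15.1%

Both compounds were tested in a functional assay on the whole organism (Tail, strain ICR) with Mus musculus as the target, in the tail flick test, with a stated time of 120 min, at a dose of 25 umol/kg by the oral route; a higher number here means a stronger effect of the compound at the dose given, a lower number a weaker effect. Compound 1 stands highest of the two numbers; compound 2 sits lower by a gap beyond the usual scatter.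

Compound 3 `C[C@@H](O)[C@H](NC(=O)CN(c1ncnc2c1ncn2C1CCCCO1)C1CC1)C(=O)OCc1ccccc1` has not yet been measured. It differs from compound 1 by 1-hydroxyethyl in place of isopropyl on a saturated chain carbon bound to an amide-type nitrogen and a carbonyl carbon. Within the data shown here, no measured pair shows this change, so its effect is uncertain; a step of a number 4.8 percentage points lower from compound 1 to compound 3 (within the scatter) is expected, a small drop within the scatter. Compound 3 is estimated at 21%, with a range from 6% to 40%.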

Compound 3, a percentage reported as activity, at one dose (the size of the read-out at that dose, not a potency): 10.9%
Compound 3: the middle estimate sits 10.1 percentage points above what was measured; the measured number falls inside the stated range.
By their numbers in this assay, from the lowest: compounds 3 and 2 (each within the scatter of the next); then compound 1.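

At this position, a saturated chain carbon bound to an amide-type nitrogen and a carbonyl carbon, 1-hydroxyethyl in place of isopropyl gives a number 14.9 percentage points lower from compound 1 to compound 3 (beyond the scatter) in this assay. The position therefore responds to a change of side chain, even one that leaves the size of the group in heavy atoms unchanged. Nothing measured here explains the drop.

From the compounds shown here alone, whether a longer chain or an amine at this place would raise or lower the number remains open. This single step also cannot show whether the same swap behaves alike on another core.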